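This account rests on a few compounds, and the source may have more. Where it says the series, first, only, none or still open, it means among the compounds named here.

Compound 1 `Cc1c(C=O)cc(-c2ccc(S(C)(=O)=O)cc2)n1-c1cccc(F)c1` gives in an assay on J774 cells for inhibition of prostaglandin G/H synthase 1 (Mus musculus), read by immunoassay, with stated times of 15 min and 30 min (on this read-out higher numbers stand for weaker inhibition and lower numbers for stronger inhibition), only a limit, > 10000 nM. Compound 2 `Cc1c(C=O)cc(-c2ccc(S(C)(=O)=O)cc2)n1-c1ccc(F)c(F)c1` likewise reaches in this assay only a limit, > 10000 nM. Among the compounds with values here, the single measured step, a step that the two limits leave unreadable from compound 1 to compound 2, cannot be read, because both values sit at the limit of > 10000 nM in this assay, at which 2 of the 2 values shown sit. Compound 3 `Cc1c(C=O)cc(-c2ccc(S(C)(=O)=O)cc2)n1-c1ccccc1` differs from compound 2 by phenyl in place of 3,4-difluorophenyl on an aromatic nitrogen. No readable step bears on this change, so no direction beyond the scatter can be drawn from the numbers shown. Compound 3 is therefore expected in this assay near 15000 nM, within 3000 nM to 80000 nM, which corresponds to an estimated step that the limit leaves unreadable from compound 2 to compound 3.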

Compound 3, half-maximal inhibitory concentration: > 10000 nM
Compound 3 was reported as a limit; the forecaster's own chance of this, stated with the estimate: 75%; the middle value is on the limit's open side.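

Within the data shown here, no step among compound 1, compound 2 and compound 3 can be read in this assay, because each value is only a limit: the limit of > 10000 nM in this assay, at which 3 of the 3 values shown sit. These compounds leave open whether fluoro in place of hydrogen on an aromatic carbon changes inhibition in this assay at all.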